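From 4-nitrophenyl to 1H-indazol-3-yl: estimating tolerated dose

This account rests on a few compounds, and the source may have more. Where it says the series, first, only, none or still open, it means among the compounds named here.

- Compound 1 `COc1ccc(CN(C)c2nc(C(C)c3c(F)cccc3F)c(C)c(=O)[nH]2)cc1`: 88800 nM
- Compound 2 `Cc1c(C(C)c2c(F)cccc2F)nc(N(C)Cc2ccc([N+](=O)[O-])cc2)[nH]c1=O`: > 50000 nM

Both compounds were tested in an ADME assay on TZM cells (Homo sapiens) for cytotoxicity, read by WST assay, with a stated time of 2 days; a higher number here means that more compound is tolerated, a lower number that less compound is tolerated. From the compounds shown here alone, compound 2 gives > 50000 nM, which is a limit and not a number, so its exact standing is unknown.

Compound 3 `Cc1c(C(C)c2c(F)cccc2F)nc(N(C)Cc2n[nH]c3ccccc23)[nH]c1=O` has not yet been measured. It differs from compound 2 as follows: 1H-indazol-3-yl in place of 4-nitrophenyl on a saturated chain carbon bound to a nitrogen on an aromatic ring. This puts 1H-indazol-3-yl in place of 4-nitrophenyl.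

Among the measured compounds shown here, the only measured step nearby is a step that the limit leaves unreadable from compound 1 to compound 2. It involves a different change, and its size cannot be read, so it offers no size or direction to carry over. No step beyond the usual scatter is therefore expected in this assay. For the measured compounds named here, the one true number as an anchor is that of compound 1, at 88800 nM.

For compound 3 the estimated value is 70000 nM, with an expected range of 25000 nM to 150000 nM. The estimate means an expected step that the limit leaves unreadable from compound 2 to compound 3.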

Compound 3, half-maximal cytotoxic concentration: > 100000 nM
Compound 3: a limit, no number (the forecaster's own chance of this, stated with the estimate: 55%); middle value at least 1.4-fold (0.15 log units) from the limit.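

In this assay, among the compounds shown here, putting 1H-indazol-3-yl in place of 4-methoxyphenyl on this saturated chain carbon gives an at least 1.1-fold higher number from compound 1 to compound 3 (0.05 log units; that floor lies within the scatter) and no sign that less compound is tolerated, so this place also accepts a group with a five-membered aromatic ring and a hydrogen-bond donor, not just the substituted phenyl groups of the earlier compounds. The steps to and from compound 2 cannot be read. Compound 3 gives > 100000 nM as a limit and not a number, so the series now reaches the top of what this reading can show: the limit of > 100000 nM in this assay, at which 1 of the 3 values shown sits.

From the compounds shown here alone, how far the true value of compound 3 lies past its limit remains open. Also open, going by these compounds, is whether a carboxylic acid or an amine on the benzyl ring at this same place would be tolerated as well.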